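The compounds below may be only part of what the source reports. "The series", "measured", "known", "first", "only" and "open" are said of these compounds alone.

Measured compounds:
compound 1 `CN(Cc1ccc2nccn2c1)c1nnc(-c2ccc(-c3ccccc3)cc2)o1` — 3.9
compound 2 `CN(Cc1ccc2nccn2c1)c1nnc(-c2ccc(-c3ccccc3F)cc2)o1` — 4.4
compound 3 `Cc1nn(C)c(C)c1-c1ccc(-c2nnc(N(C)Cc3ccc4nccn4c3)o2)cc1` — 3.1

In a physicochemical assay for lipophilicity, at pH 7.4 (a higher number here means a more lipophilic compound, a lower number a more polar compound), the three compounds share one core and differ at one end of it. The change fluoro in place of hydrogen on an aromatic carbon made the step of a number 0.50 log units higher from compound 1 to compound 2 (beyond the scatter). The change 1,3,5-trimethyl-1H-pyrazol-4-yl in place of phenyl on an aromatic carbon made the step of a number 0.80 log units lower from compound 1 to compound 3 (beyond the scatter), and from compound 2 the step is a number 1.30 log units lower from compound 2 to compound 3 (beyond the scatter).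

Compound 4 `Cc1nn(C)c(C)c1-c1ccc(-c2nnc(N(C)Cc3ccc4nccn4c3)o2)c(F)c1` carries the change fluoro in place of hydrogen on an aromatic carbon relative to compound 3. This is the same kind of change as from compound 1 to compound 2, but the place is not identical: here the entering fluoro is also meta to a 1,3,5-trimethyl-1H-pyrazol-4-yl group. Compound 4 is expected to move by a number 0.45 log units higher from compound 3 to compound 4 (beyond the scatter), close to the earlier step of a number 0.50 log units higher from compound 1 to compound 2 (beyond the scatter), resting only on that one pair. Compound 4 is therefore estimated at 3.55, between 3.2 and 3.9.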

Compound 4, distribution coefficient: 3.2
For compound 4 the middle estimate is 0.35 log units above the measured one; low and high end bracket the measured number.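

In this assay the change to fluoro gave a number 0.50 log units higher from compound 1 to compound 2 (beyond the scatter) but gave a number 0.10 log units higher from compound 3 to compound 4 (within the scatter) on the other compound pair, so the size of the first step did not carry over. The two pairs differ both in the group at the end of the core and in where the fluoro sits; here it is ortho to a large group and meta to a 1,3,5-trimethyl-1H-pyrazol-4-yl group, and these two pairs cannot separate those differences. No measurement shown gives a reason for the result.

Still open, going by these compounds, is whether the fluoro would give a larger step on this core at another carbon. Also open, on these data alone, is how a chloro or methoxy group in its place would read in this assay on either core.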